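Cyclohexyl in Place of Cyclohexylmethyl: an Estimate

The source may report more compounds than this note shows. Statements on the series, on what has been measured and on what is new or still open speak of the compounds shown alone.

Measured compounds:
Compound 1 `COc1cc(NC(C)CCCNC(=O)NCC2CCCCC2)c2ncccc2c1`: in a functional assay on NCI-H460 cells (Homo sapiens), read by MTT assay, with a stated time of 72 h (on this read-out higher numbers stand for weaker inhibition and lower numbers for stronger inhibition), compound 1 gives > 100000 nM, which is a limit of the assay rather than a number.
Compound 2 `COc1cc(NC(C)CCCNC(=O)NCc2ccncc2)c2ncccc2c1`: in this assay compound 2 gives 48000 nM.
Compound 3 `COc1cc(NC(C)CCCNC(=O)N(C2CCCCC2)C2CCCCC2)c2ncccc2c1`: in this assay compound 3 gives 21000 nM.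

Compound 1 therefore stands at the limit of > 100000 nM in this assay, at which 1 of the 3 values shown sits, so its true value is not pinned down. Compound 4 `COc1cc(NC(C)CCCNC(=O)NC2CCCCC2)c2ncccc2c1` differs from it by cyclohexyl in place of cyclohexylmethyl on an amide-type nitrogen. Going by the values given here, the only measured single change, an at least 2.0-fold lower number from compound 1 to compound 2 (0.31 log units; beyond the scatter), swaps the ring itself, not the chain that joins it to the nitrogen, so no measured step speaks directly to this shortening. With nothing to point the other way, compound 4 is expected to stay near the limit, with a number no higher from compound 1 to compound 4 (the limit leaves the size open) as the estimated step. Compound 4 is estimated at 100000 nM, within a range from 30000 nM to 300000 nM.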

Compound 4, half-maximal inhibitory concentration: 77000 nM
Estimate against measurement, compound 4: 1.3-fold (0.11 log units) above, and the stated range covers the measured number.
By their numbers in this assay, from the lowest: compound 3; then compounds 2 and 4 (each within the scatter of the next). At a limit, above all of these: compound 1.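

Shortening cyclohexylmethyl to cyclohexyl on the amide-type nitrogen gives an at least 1.2-fold lower number from compound 1 to compound 4 (0.11 log units; that floor lies within the scatter), and the true size of this step stays unknown because the value of compound 1 is a limit, not a number: the limit of > 100000 nM in this assay, at which 1 of the 4 values shown sits. Replacing (pyridin-4-yl)methyl with cyclohexyl at this nitrogen gives a 1.6-fold higher number from compound 2 to compound 4 (0.21 log units; within the scatter), so these two groups cannot be told apart in this assay. Replacing the second cyclohexyl on this nitrogen with hydrogen gives a clearer change, a 3.7-fold higher number from compound 3 to compound 4 (0.56 log units; beyond the scatter).

As far as these compounds go, it remains open how an amine or a carboxylic acid on the cyclohexyl ring would change the number. From the compounds shown here alone, the effect of a longer chain between that ring and the nitrogen is also open.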